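The source may hold more compounds than are shown below. What is called first, only, known or untested is meant among the compounds shown, and "the series" means these compounds.

Three close relatives share one core and are all measured in a functional assay on cells for negative allosteric modulation of metabotropic glutamate receptor 5 (Homo sapiens), read by fluorescence and calcium flux, with a stated time of 20 min; on this read-out lower numbers stand for stronger inhibition and higher numbers for weaker inhibition. Compound 1 `O=S(=O)(c1cc(Cl)cc(Cl)c1)c1cnc2cc(F)ccc2c1-c1cccc(F)c1` gives 35 nM. Compound 2 `O=S(=O)(c1cc(Cl)cc(Cl)c1)c1cnc2c(F)cccc2c1-c1ccc(F)cc1` gives 25 nM, and compound 3 `O=S(=O)(c1cc(Cl)cc(Cl)c1)c1cnc2cc(F)ccc2c1-c1ccc(F)cc1` gives 25 nM. Compound 1 thus has the highest of the three numbers, yet its values against compound 2 and against compound 3 both sit within the usual scatter of this assay, so the three are not separated by it. Going by the values given here, the only single-point step among them, a 1.4-fold lower number from compound 1 to compound 3 (0.15 log units; within the scatter), confirms that moving a fluorine on the aryl ring attached to the core changes little.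

Compound 4 `O=S(=O)(c1cc(F)cc(F)c1)c1cnc2cc(F)ccc2c1-c1cccc(F)c1` differs from compound 1 in another place: 3,5-difluorophenyl in place of 3,5-dichlorophenyl on a sulfonyl sulfur. Among the compounds with values here, no measured step touches this sulfonyl-bound aryl; every change recorded so far concerns fluorine on the other two rings. The expectation therefore rests on the structural change alone, and for compound 4 the expected number is 200 nM, with a range from 50 nM to 800 nM, a step of a 5.7-fold higher number from compound 1 to compound 4 (0.76 log units; beyond the scatter) expected towards weaker inhibition.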

Compound 4, half-maximal inhibitory concentration: 74 nM
Beside the measured number, compound 4's estimate is 2.7-fold (0.43 log units) above it, and the stated range covers the measured number.
By their numbers in this assay, from the lowest: compounds 2, 3 and 1 (each within the scatter of the next); then compound 4.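

Going by these compounds alone, the ring on the sulfonyl sulfur is the first place where a single change moves the number beyond the usual scatter: in this assay, replacing 3,5-dichlorophenyl with 3,5-difluorophenyl gives a 2.1-fold higher number from compound 1 to compound 4 (0.33 log units; beyond the scatter), a modest loss. The two groups have the same ring and the same count of heavy atoms, so the step follows from the exchange of chlorine for fluorine alone. Nothing available explains why the number moves with this exchange.

The step has been read only once, with a 3-fluorophenyl ring on the core, so it may not hold alongside the other fluorine patterns. The compounds shown also carry only two halogens on the sulfonyl-bound ring, which leaves the effect of a methyl, methoxy, nitrile or amine group there unknown.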